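Halogen on the cinnamoyl aryl ring: step to compound 4

The compounds below may be only part of what the source reports. "The series", "measured", "known", "first", "only" and "open" are said of these compounds alone.

Measured compounds in a functional assay on PC-3 cells (Homo sapiens) for antiproliferative activity, read by MTT assay, with a stated time of 72 h; a higher number here means a weaker inhibitor, a lower number a stronger inhibitor:
- compound 1 `O=C(COc1ccc(C(=O)/C=C/c2ccc(Cl)cc2Cl)cc1)N[C@H]1CCOC1=O`: 8040 nM
- compound 2 `O=C(COc1ccc(C(=O)/C=C/c2ccc(F)c(F)c2)cc1)N[C@H]1CCOC1=O`: 21900 nM
- compound 3 `O=C(COc1ccc(C(=O)/C=C/c2ccccc2)cc1)N[C@H]1CCOC1=O`: 56800 nM

Compound 3 carries the unsubstituted aryl ring on the double-bonded chain and gives the highest number of the three in this assay; its steps to both other compounds are beyond the scatter, so it is the weakest inhibitor of the set.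

Compound 4 `O=C(COc1ccc(C(=O)/C=C/c2ccccc2Br)cc1)N[C@H]1CCOC1=O` differs from compound 3 by bromo in place of hydrogen on an aromatic carbon, on an aromatic carbon of a six-membered aromatic ring of carbon only, ortho to a large group.

Both measured steps that end at compound 3 bear on this change, since each removes halogen from that ring: a 7.1-fold higher number from compound 1 to compound 3 (0.85 log units; beyond the scatter) and a 2.6-fold higher number from compound 2 to compound 3 (0.41 log units; beyond the scatter). Both run toward higher numbers when halogen leaves, so adding a single bromo is expected to move the number down, by a modest amount, likely smaller than the step seen with two chlorines in compound 1.

The estimate for compound 4 is therefore 20000 nM, range 8000 nM to 50000 nM, that is an expected step of a 2.8-fold lower number from compound 3 to compound 4 (0.45 log units; beyond the scatter).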

Compound 4, half-maximal inhibitory concentration: 3260 nM
Beside the measured number, compound 4's estimate is 6.1-fold (0.79 log units) above it; the whole stated range lies above it.
By their numbers in this assay, from the lowest: compound 4; then compound 1; then compound 2; then compound 3.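

In this assay, bromo in place of hydrogen on this aromatic carbon, ortho to a large group, gives a 17-fold lower number from compound 3 to compound 4 (1.24 log units; beyond the scatter), so one substituent on the otherwise unsubstituted ring accounts for the largest change in the set. The 2-bromophenyl ring also outperforms both dihalogenated rings, with a 6.7-fold lower number from compound 2 to compound 4 (0.83 log units; beyond the scatter) and a 2.5-fold lower number from compound 1 to compound 4 (0.39 log units; beyond the scatter), making compound 4 the strongest inhibitor of the four and showing that the amount of halogen alone does not order these compounds. No measurement is available that explains this gain.

The compounds shown leave open whether the gain follows bromine itself or its place on the ring, a question that 2-chlorophenyl and 4-bromophenyl analogues would address. They also leave open whether a non-halogen group at this place, such as methyl or an amine, would give a similar number.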